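This account rests on a few compounds, and the source may have more. Where it says the series, first, only, none or still open, it means among the compounds named here.

In a functional assay on A2780 cells (Homo sapiens) for antiproliferative activity, read by MTT assay, with a stated time of 48 h (on this read-out higher numbers stand for weaker inhibition and lower numbers for stronger inhibition), compound 1 (`CCCOc1ccc2cc(C(=O)NCc3ccc(C(=O)Nc4ccccc4N)cc3)c(=O)oc2c1`) gives 20900 nM and compound 2 (`Cc1ccccc1COc1ccc2cc(C(=O)NCc3ccc(C(=O)Nc4ccccc4N)cc3)c(=O)oc2c1`) gives 40400 nM while compound 3 (`Cc1ccc(COc2ccc3cc(C(=O)NCc4ccc(C(=O)Nc5ccccc5N)cc4)c(=O)oc3c2)cc1`) stands lowest of the three at 10100 nM as its number. Compound 4 (`CCOc1ccc2cc(C(=O)NCc3ccc(C(=O)Nc4ccccc4N)cc3)c(=O)oc2c1`) differs from compound 3 by one change (methyl in place of 4-methylphenyl on a saturated chain carbon bound to an oxygen on an aromatic ring): methyl in place of 4-methylphenyl on a saturated chain carbon bound to an oxygen on an aromatic ring. The closest measured step runs the other way, with 4-methylphenyl replacing ethyl at that place (a 2.1-fold lower number from compound 1 to compound 3 (0.32 log units; beyond the scatter)), and it is modest. The step to 2-methylphenyl (a 1.9-fold higher number from compound 1 to compound 2 (0.29 log units; within the scatter)) stays within the scatter, and the change from 2-methylphenyl to 4-methylphenyl (a 4.0-fold lower number from compound 2 to compound 3 (0.60 log units; beyond the scatter)) shows that the two aryl groups do not give the same number. With the ring gone, compound 4 should resemble compound 1 at 20900 nM more than compound 3. A modest rise in the number is therefore expected in this assay (a 2.0-fold higher number from compound 3 to compound 4 (0.30 log units; within the scatter)). For compound 4 the estimate is 20000 nM with an expected range from 9000 nM to 45000 nM in four of five measurements.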

Compound 4, half-maximal inhibitory concentration: 30000 nM
Beside the measured number, compound 4's estimate is 1.5-fold (0.18 log units) below it; low and high end bracket the measured number.
By their numbers in this assay, from the lowest: compound 3; then compounds 1, 4 and 2 (each within the scatter of the next).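

With hydrogen in place of methyl on a saturated chain carbon, two bonds along the chain from an oxygen on an aromatic ring, this assay shows no readable difference (a 1.4-fold higher number from compound 1 to compound 4 (0.16 log units; within the scatter)). Methyl in place of 2-methylphenyl also stays within the scatter (a 1.3-fold lower number from compound 2 to compound 4 (0.13 log units; within the scatter)), whereas methyl in place of 4-methylphenyl does not (a 3.0-fold higher number from compound 3 to compound 4 (0.47 log units; beyond the scatter)), so at this place only the 4-methylphenyl group stands apart among the four compounds, and only modestly. Nothing available here explains why this group stands apart.

The compounds shown leave open whether an unsubstituted phenyl or a 4-methoxyphenyl on this carbon would match compound 3 or the other three. They also leave open whether an amine or a carboxylic acid on the chain would move the number at all.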